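Trifluoromethylphenyl isomer swap from compound 1 to compound 4

The source may report more compounds than this note shows. Statements on the series, on what has been measured and on what is new or still open speak of the compounds shown alone.

In a functional assay on MOLT-4 cells (Homo sapiens) for inhibition, read by MTT assay, with a stated time of 72 h (on this read-out lower numbers stand for stronger inhibition and higher numbers for weaker inhibition), compound 1 (`COc1cc(NC(C)CCCNC(=O)NNC(=O)Nc2ccc(C(F)(F)F)cc2)c2ncccc2c1`) gives 24000 nM. Compound 2 (`COc1cc(NC(C)CCCNC(=O)Nc2ccc(C(F)(F)F)cc2)c2ncccc2c1`) gives 20000 nM, and compound 3 (`COc1cc(NC(C)CCCNC(=O)Nc2cccc(C(F)(F)F)c2)c2ncccc2c1`) gives 20000 nM. All three numbers lie within the scatter of one another, so compound 1 stands level with the other two.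

Compound 4 (`COc1cc(NC(C)CCCNC(=O)NNC(=O)Nc2cccc(C(F)(F)F)c2)c2ncccc2c1`) has not yet been measured. Its structural change from compound 1 is 3-(trifluoromethyl)phenyl in place of 4-(trifluoromethyl)phenyl on an amide-type nitrogen. The two compounds have the same atoms, joined differently.

One measured step carries the same replacement, and it shows no change at the digits printed from compound 2 to compound 3 (within the scatter). This is a single pair, and nothing measured tests the replacement on the chain of compound 1 itself. On that evidence, no step beyond the scatter is expected in this assay, and no direction is favoured. The expected step is a 1.1-fold lower number from compound 1 to compound 4 (0.04 log units; within the scatter). Compound 4 is estimated at 22000 nM, with an expected range of 12000 nM to 40000 nM.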

Compound 4, half-maximal inhibitory concentration: 36000 nM
Beside the measured number, compound 4's estimate is 1.6-fold (0.21 log units) below it, within the range that was stated.
By their numbers in this assay, from the lowest: compounds 2, 3, 1 and 4 (each within the scatter of the next).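

In this assay, 3-(trifluoromethyl)phenyl in place of 4-(trifluoromethyl)phenyl on an amide-type nitrogen now has a reading on a second core, with a 1.5-fold higher number from compound 1 to compound 4 (0.18 log units; within the scatter). The step lies within the scatter on both cores, and the two steps also agree with each other within the scatter: the same change on two cores in this assay, no change at the digits printed (within the scatter) from compound 2 to compound 3 and a 1.5-fold higher number (0.18 log units; within the scatter) from compound 1 to compound 4, 1.5-fold (0.18 log units) apart, within the scatter of two such steps

For the compounds shown here, at this position, the read-out therefore does not separate the two trifluoromethylphenyl isomers on either core, although this rests on only two pairs.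

Still open, from the compounds shown here alone, is whether the read-out at this position responds to the group on the phenyl ring at all, since all four compounds carry trifluoromethyl. A nitrile, a carboxylic acid or an amine in its place, or a plain phenyl, would address that question.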